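Second chloro in place of fluoro on the shared core

A few compounds are considered here, and "the series" means these few. Any claim that something is new, unique, unknown or untested is made for them only; others in the source may bear on it.

Compound 2 `COc1ccc(C(=O)Nc2c(F)c(F)nc(F)c2Cl)cc1OC1CCCC1` holds the lowest of the two numbers in an assay on isolated protein for inhibition of phosphodiesterase 4A (Sus scrofa) (on this read-out lower numbers stand for stronger inhibition and higher numbers for weaker inhibition), with 100 nM; compound 1 `COc1ccc(C(=O)Nc2c(F)c(F)nc(F)c2F)cc1OC1CCCC1` gives 550 nM. Compound 3 `COc1ccc(C(=O)Nc2c(Cl)c(F)nc(F)c2Cl)cc1OC1CCCC1` differs from compound 2 by chloro in place of fluoro on an aromatic carbon. Within the data shown here, the one measured step that bears on this change is of the same kind, a 5.5-fold lower number from compound 1 to compound 2 (0.74 log units; beyond the scatter). A second exchange of this type is expected to repeat only part of that lowering, so the step from compound 2 to compound 3 is estimated as a 2.0-fold lower number from compound 2 to compound 3 (0.30 log units; within the scatter). Compound 3 is therefore expected at 50 nM, with a range from 20 nM to 150 nM.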

Compound 3, half-maximal inhibitory concentration: 20 nM
Compound 3: the middle estimate sits 2.5-fold (0.40 log units) above what was measured, and the stated range covers the measured number.
By their numbers in this assay, from the lowest: compound 3; then compound 2; then compound 1.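

In this assay, chloro in place of fluoro at this position, ortho to a large group and para to a fluoro group, gives a 5.0-fold lower number from compound 2 to compound 3 (0.70 log units; beyond the scatter) and so shows no fading next to the earlier exchange, a 5.5-fold lower number from compound 1 to compound 2 (0.74 log units; beyond the scatter) on the same core. Both steps lie beyond the scatter, so the lowering holds across two successive exchanges of this kind. Nothing measured here accounts for it. On these data alone, whether bromo or methyl at this position would extend the lowering remains open. So does the effect of replacing the two remaining fluoro groups with chloro.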